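Swapping a pyridine for a phenyl on a thiourea

The source may report more compounds than this note shows. Statements on the series, on what has been measured and on what is new or still open speak of the compounds shown alone.

Of the compounds shown here, two have been measured so far in an assay for inhibition of epoxide hydrolase 1 (Homo sapiens), read by fluorescence, using microsomes; a higher number here means a weaker inhibitor, a lower number a stronger inhibitor. Compound 1 `Cc1ccccc1NC(=S)NC(=O)c1ccccc1` gives 3540 nM in this assay. Compound 2 `O=C(NC(=S)Nc1ccncc1)c1ccccc1` gives 2280 nM in this assay, the lower of the two numbers, but the gap to compound 1 lies within the scatter, so the two cannot be ranked against each other.

The next compound, compound 3 `O=C(NC(=S)Nc1ccccc1)c1ccccc1`, differs from compound 2 in one place: phenyl in place of pyridin-4-yl on an amide-type nitrogen. Within the data shown here, no measured pair shows this kind of change, so nothing in the data indicates how large a step to expect. The two measured compounds, which differ elsewhere, sit within the scatter of each other, and a step of no more than the scatter seems most likely, in either direction. The expected step from compound 2 to compound 3 is a 1.1-fold higher number from compound 2 to compound 3 (0.04 log units; within the scatter) in this assay. Compound 3 is estimated to give 2500 nM in this assay, within a range of 800 nM to 8000 nM.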

Compound 3, half-maximal inhibitory concentration: 1290 nM
The estimate for compound 3 lay 1.9-fold (0.29 log units) above the measured number, and the stated range covers the measured number.
By their numbers in this assay, from the lowest: compounds 3, 2 and 1 (each within the scatter of the next, the first and the last beyond it).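

In this assay phenyl in place of pyridin-4-yl on an amide-type nitrogen gives a 1.8-fold lower number from compound 2 to compound 3 (0.25 log units; within the scatter) and so the data cannot show that the ring nitrogen and its hydrogen-bond acceptor help or harm inhibition. Hydrogen in place of methyl on an aromatic carbon gives a 2.7-fold lower number from compound 1 to compound 3 (0.44 log units; beyond the scatter) in this assay and this modest step is the only one of the two to lie beyond the scatter. No separate measurement bears on the reason for either step.

The compounds shown leave open how a saturated ring such as cyclohexyl would fare on the amide-type nitrogen. They also leave open whether a chlorine atom or a methoxy group in place of that methyl would give a higher number than hydrogen does.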